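The source may report more compounds than this note shows. Statements on the series, on what has been measured and on what is new or still open speak of the compounds shown alone.

Measured compounds in a functional assay on WHCO1 cells (Homo sapiens) for cytotoxicity, read by MTT assay, with a stated time of 24 h; a lower number here means a stronger inhibitor, a higher number a weaker inhibitor:
compound 1 `C=CC(O)C1=CC(=O)c2ccccc2C1=O` — 4300 nM
compound 2 `O=C1C=C(C(O)c2ccc(Cl)cc2)C(=O)c2ccccc21` — 3000 nM
compound 3 `O=C1C=C(C(O)c2cccc(F)c2)C(=O)c2ccccc21` — 5500 nM

Compound 3 gives the largest of the three numbers, but neither gap separates it: a 1.3-fold higher number from compound 1 to compound 3 (0.11 log units; within the scatter) and a 1.8-fold higher number from compound 2 to compound 3 (0.26 log units; within the scatter) both lie within the scatter. The three compounds are, on this evidence, indistinguishable in this assay.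

Compound 4 `O=C1C=C(C(O)c2cccc(Cl)c2)C(=O)c2ccccc21` is the next step: chloro in place of fluoro on an aromatic carbon. Within the data shown here, no measured step isolates this swap. Among the measured compounds shown here, the only step that involves both halogens, a 1.8-fold higher number from compound 2 to compound 3 (0.26 log units; within the scatter), also moves the position and was itself within the scatter. The expectation for compound 4 is therefore a step of no more than the scatter in this assay, a 1.4-fold lower number from compound 3 to compound 4 (0.14 log units; within the scatter), with a slight lean toward a lower number because compound 2 gave 3000 nM. Compound 4 is estimated at 4000 nM, range 2000 nM to 9000 nM.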

Compound 4, half-maximal inhibitory concentration: 7300 nM
The estimate for compound 4 lay 1.8-fold (0.26 log units) below the measured number; low and high end bracket the measured number.
By their numbers in this assay, from the lowest: compounds 2, 1, 3 and 4 (each within the scatter of the next, the first and the last beyond it).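

In this assay the swap of fluoro for chloro is now isolated, and a 1.3-fold higher number from compound 3 to compound 4 (0.12 log units; within the scatter) separates neither halogen from the other at this place. The chlorine's position does register, as 3-chlorophenyl in place of 4-chlorophenyl gives a 2.4-fold higher number from compound 2 to compound 4 (0.39 log units; beyond the scatter) and this modest step is the only one shown beyond the scatter, while a 1.7-fold higher number from compound 1 to compound 4 (0.23 log units; within the scatter) leaves 3-chlorophenyl unseparated from vinyl. Nothing available speaks to the cause of these steps.

Open, from the compounds shown here alone, is whether an amine or a carboxylic acid on the aromatic ring would move the number beyond the scatter.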